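Lipophilicity notes: pyrazolyl carboxamide to methylpyridinyl on the shared core

A few compounds are considered here, and "the series" means these few. Any claim that something is new, unique, unknown or untested is made for them only; others in the source may bear on it.

Measured so far in a physicochemical assay for lipophilicity, using the shake flask method, in phosphate buffer, measured as octanol-water partition, with a stated time of 30 min, at pH 7.4; a higher number here means a more lipophilic compound, a lower number a more polar compound:
compound 1, `CNC(=O)c1cc(-c2cnc(NCc3c(F)ccc4c3CCO4)c3cn[nH]c(=O)c23)n(C)n1` — 2.1
compound 2, `O=C(Nc1ccccc1)c1cnc(NCc2c(F)ccc3c2CCO3)n2cnnc12` — 4.1
compound 3, `CN(c1ncco1)c1cnc(NCc2c(F)ccc3c2CCO3)n2cnnc12` — 2.1

Compound 1 stands level with compound 3 at the digits shown, and these two together give the lowest numbers of the three; compound 2 is the furthest from compound 1, higher by a margin well beyond the scatter. Among the measured compounds shown here, only one single-point step is available, a number 2.00 log units lower from compound 2 to compound 3 (beyond the scatter), where a phenylcarbamoyl is exchanged for a methyl(1,3-oxazol-2-yl)amino group; it shows that swapping a carboxamide-bearing substituent for a small heteroaryl moves this assay by a large amount.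

Compound 4, `Cc1ncccc1-c1cnc(NCc2c(F)ccc3c2CCO3)c2cn[nH]c(=O)c12`, is not yet measured. It differs from compound 1 in one place: 2-methylpyridin-3-yl in place of 1-methyl-3-(methylcarbamoyl)-1H-pyrazol-5-yl on an aromatic carbon. The group that leaves carries the hydrogen-bond donor of the methylcarbamoyl and two further acceptors; the group that enters has none of that donor and a single acceptor. The step between compound 2 and compound 3 does not match this change directly, but it shows that removing a carboxamide from the substituent at this position is worth well over the scatter. The expected direction for compound 4 is therefore upward, by about a number 1.00 log units higher from compound 1 to compound 4 (beyond the scatter). Compound 4 is estimated at 3.1, with a plausible range from 2.5 to 3.7.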

Compound 4, distribution coefficient: 3
Beside the measured number, compound 4's estimate is 0.10 log units above it; measured number inside the range.
By their numbers in this assay, from the lowest: compounds 1 and 3 (each within the scatter of the next); then compound 4; then compound 2.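

On the core of compound 1, the aromatic carbon para to a large group now has a direct reading in this assay: 2-methylpyridin-3-yl in place of 1-methyl-3-(methylcarbamoyl)-1H-pyrazol-5-yl gives a number 0.90 log units higher from compound 1 to compound 4 (beyond the scatter), a modest step. Among the compounds shown here, the earlier step, a number 2.00 log units lower from compound 2 to compound 3 (beyond the scatter), involves different groups on a different core, so this is the first step to come from the core of compound 1. The exchange changes the ring size, the heavy-atom count and the hydrogen-bond donors and acceptors all at once, and no measurement shown ties the step to any one of these differences.

Still open, on these data alone, is how far the methylcarbamoyl alone contributes, which 1-methyl-1H-pyrazol-5-yl or an unsubstituted pyridin-3-yl on the same core would begin to separate from the change of ring. Also open, as far as these compounds go, is how a group of another kind at this place, such as an amine or a carboxylic acid, would read in this assay.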